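Oxetanol replacement on the thiophene-side substituent of compound 3

The source may report more compounds than this note shows. Statements on the series, on what has been measured and on what is new or still open speak of the compounds shown alone.

Working notes on the series. Compound 1 `Cc1cc(Cl)cc(-c2ccnc3cc(CN4C(=O)C5C(C4=O)C5(C)C)sc23)c1NC1CCCNC1` gives 0.78 nM in an assay on isolated protein for inhibition of ubiquitin carboxyl-terminal hydrolase 7 (Homo sapiens), read by fluorescence, with stated times of 30 min and 1 h; a lower number here means a stronger inhibitor, a higher number a weaker inhibitor; compound 2 `Cc1cc(Cl)cc(-c2ccnc3cc(CN4C(=O)CCC4=O)sc23)c1OC1CCNCC1` gives 8 nM; compound 3 `O=C([C@H]1Cc2cc(Cl)cc(-c3ccnc4cc(C(O)(CO)CCl)sc34)c2O1)N1CCNCC1` gives 9 nM. Compound 3 carries the highest of the three numbers, yet its gap to compound 2 lies within the scatter, while compound 1 sits well beyond it. Compound 4 `O=C([C@H]1Cc2cc(Cl)cc(-c3ccnc4cc(C5(O)COC5)sc34)c2O1)N1CCNCC1` is the next member, still unmeasured. Its change from compound 3 is 3-hydroxyoxetan-3-yl in place of 1-(chloromethyl)-1,2-dihydroxyethyl on an aromatic carbon, placed on an aromatic carbon of the five-membered aromatic ring with one sulfur in the fused system. Among the measured compounds shown here, no pair of measured compounds shows this step, so its size is unknown. The tertiary hydroxyl is kept, so compound 4 is expected to give 8 nM (range 2.5 nM to 25 nM), a step of a 1.1-fold lower number from compound 3 to compound 4 (0.05 log units; within the scatter) that is not expected to exceed the scatter.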

Compound 4, half-maximal inhibitory concentration: 73 nM
Compound 4: middle estimate off by 9.1-fold (0.96 log units), on the low side; the measured number lies above the stated range.
By their numbers in this assay, from the lowest: compound 1; then compounds 2 and 3 (each within the scatter of the next); then compound 4.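

At this position, on an aromatic carbon of a five-membered aromatic ring with 1 sulfur, next to the ring sulfur, the side group is not interchangeable in this assay. Putting 3-hydroxyoxetan-3-yl in place of 1-(chloromethyl)-1,2-dihydroxyethyl gives an 8.1-fold higher number from compound 3 to compound 4 (0.91 log units; beyond the scatter) and this lies beyond the scatter. Keeping the tertiary hydroxyl is thus not enough to hold the number of compound 3.

Still open, as far as these compounds go, is whether an open 1,2-dihydroxyethyl group without the chlorine, or a primary amine in place of the oxetane hydroxyl, would stay near compound 3. Nothing measured on these compounds accounts for the step.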